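This account rests on a few compounds, and the source may have more. Where it says the series, first, only, none or still open, it means among the compounds named here.

Of the compounds shown here, three sharing one core have been measured in an assay on isolated protein for inhibition of protein deacetylase HDAC6 (Homo sapiens), read by fluorescence, with a stated time of 1 h, tested at 100 nM; a higher number here means more inhibition at the concentration tested (going by the name of the read-out), a lower number less inhibition. Compound 1 `CCCN1CCC(c2noc(COc3ccc(/C=C/C(=O)NO)cc3)n2)CC1` gives 69%, compound 2 `Cc1cccc(CN2CCC(c3noc(COc4ccc(/C=C/C(=O)NO)cc4)n3)CC2)c1` gives 73%, and compound 3 `O=C(/C=C/c1ccc(OCc2nc(C3CCN(Cc4ccc(Br)cc4)CC3)no2)cc1)NO` gives 58%. Compound 3 stands lowest of the three: the change from compound 1 is a number 11 percentage points lower from compound 1 to compound 3 (beyond the scatter), and from compound 2 it is a number 15 percentage points lower from compound 2 to compound 3 (beyond the scatter), while a number 4 percentage points higher from compound 1 to compound 2 (within the scatter) separates compounds 1 and 2. Compound 4 `N#Cc1ccc(CN2CCC(c3noc(COc4ccc(/C=C/C(=O)NO)cc4)n3)CC2)cc1` has not yet been measured in this assay. It differs from compound 3 by cyano in place of bromo on an aromatic carbon, the cyano taking the place occupied by the bromo on the 4-bromophenyl. For the measured compounds named here, none of the measured steps changes a group on that aromatic carbon; all three swap the whole group on the saturated chain carbon bound to the amine nitrogen in the ring. There is therefore nothing to show whether cyano behaves differently from bromo here, and the expected step of a number 4 percentage points higher from compound 3 to compound 4 (within the scatter) is small, not beyond the scatter. Compound 4 is estimated at 62%, within a range from 48% to 76%.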

Compound 4, a percentage reported as inhibition, at one concentration (the size of the read-out at that concentration, not a potency): 65%
Beside the measured number, compound 4's estimate is 3 percentage points below it, and the stated range covers the measured number.
By their numbers in this assay, from the lowest: compounds 3, 4, 1 and 2 (each within the scatter of the next, the first and the last beyond it).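

In this assay, for the compounds shown here, this is the first step that changes only the group on the aromatic carbon para to a large group, and cyano in place of bromo gives a number 7 percentage points higher from compound 3 to compound 4 (within the scatter), so this swap shows no difference beyond the scatter. Compound 3 stood apart from both other compounds by steps beyond the scatter, whereas the 4-cyanophenyl group gives a number 8 percentage points lower from compound 2 to compound 4 (within the scatter) and a number 4 percentage points lower from compound 1 to compound 4 (within the scatter), which leaves compound 4 within the scatter of all three. Nothing available explains these results.

The compounds shown cannot tell whether cyano and bromo truly differ at this carbon, since their gap is no larger than repeat measurements can produce. As far as these compounds go, it also remains open whether an amine or a carboxylic acid on the same carbon would give a step beyond the scatter.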